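Para-Substituted Chalcone Boronates: Cytotoxicity on Breast Epithelial Cells

The compounds below may be only part of what the source reports. "The series", "measured", "known", "first", "only" and "open" are said of these compounds alone.

The measured compounds and their numbers:
compound 1, `O=C(/C=C/c1ccc2c(c1)B(O)OC2)c1ccccc1`, 15900 nM
compound 2, `CSc1ccc(C(=O)/C=C/c2ccc3c(c2)B(O)OC3)cc1`, 7400 nM
compound 3, `O=C(/C=C/c1ccc2c(c1)B(O)OC2)c1ccc(C(F)(F)F)cc1`, 22300 nM

In a toxicity assay on MCF-10A cells (Homo sapiens) for cytotoxicity, read by MTT assay, with a stated time of 48 h (on this read-out higher numbers stand for weaker inhibition and lower numbers for stronger inhibition), compound 1 gives 15900 nM, the second highest of the three numbers. Its nearest neighbour is compound 3, and the step of a 1.4-fold higher number from compound 1 to compound 3 (0.15 log units; within the scatter) is within the scatter, so the two cannot be ordered. Among the measured compounds shown here, the step of a 2.1-fold lower number from compound 1 to compound 2 (0.33 log units; beyond the scatter) lies beyond the scatter and is the only change among the three that moved the number clearly. Between compounds 2 and 3 the step of a 3.0-fold higher number from compound 2 to compound 3 (0.48 log units; beyond the scatter) is also beyond the scatter.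

Compound 4, `CCOC(=O)c1ccc(C(=O)/C=C/c2ccc3c(c2)B(O)OC3)cc1`, differs from compound 1 by the change (ethoxycarbonyl in place of hydrogen on an aromatic carbon). The two measured steps that bear on it are substitutions at the same aromatic carbon: a 2.1-fold lower number from compound 1 to compound 2 (0.33 log units; beyond the scatter) and a 1.4-fold higher number from compound 1 to compound 3 (0.15 log units; within the scatter). One is a modest move down, the other within the scatter, so no change at this position has yet exceeded a modest size in either direction. For the measured compounds named here, neither group resembles ethoxycarbonyl, so there is no direct precedent. Compound 4 is therefore expected to stay close to compound 1, with a step of a 1.1-fold lower number from compound 1 to compound 4 (0.06 log units; within the scatter) that is expected to fall within or only just beyond the scatter. Compound 4 is estimated at 14000 nM, within a range of 6000 nM to 35000 nM.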

Compound 4, half-maximal inhibitory concentration: 12900 nM
For compound 4 the middle estimate is 1.1-fold (0.04 log units) above the measured one, and the stated range covers the measured number.
By their numbers in this assay, from the lowest: compounds 2, 4, 1 and 3 (each within the scatter of the next, the first and the last beyond it).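

In this assay, ethoxycarbonyl, with its 5 heavy atoms and no ring, enters on the aromatic carbon para to a large group with no change that can be told from the scatter (a 1.2-fold lower number from compound 1 to compound 4 (0.09 log units; within the scatter)). The earlier compounds had shown only the single-group replacements methylsulfanyl and trifluoromethyl at this carbon, and the larger ester now adds a third group that leaves the number of compound 1 unresolved from its own. It is equally unresolved from the other two substituted compounds (a 1.7-fold lower number from compound 3 to compound 4 (0.24 log units; within the scatter)) and (a 1.7-fold higher number from compound 2 to compound 4 (0.24 log units; within the scatter)), even though those two are separated beyond the scatter (a 3.0-fold higher number from compound 2 to compound 3 (0.48 log units; beyond the scatter)), so compound 4 cannot be ordered against any of the other three.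

No measured evidence is at hand on what lies behind these numbers. On these data alone, whether a carboxylic acid, an amide, an amine or a longer ester chain on this aromatic carbon would move the number clearly beyond the scatter, in either direction, remains open.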